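This account rests on a few compounds, and the source may have more. Where it says the series, first, only, none or still open, it means among the compounds named here.

Of the compounds shown here, three share a core and have been tested in a physicochemical assay for lipophilicity, measured as octanol-water partition; on this read-out higher numbers stand for higher lipophilicity and lower numbers for lower lipophilicity. Compound 1, `CCO/N=C/Nc1cc(Cl)c(CC)c(Cl)c1`, gives 4.8 in this assay. Compound 2, `CCO/N=C/Nc1cc(Cl)c(S(=O)(=O)CC)c(Cl)c1`, gives 2.8. Compound 3, `C#CCc1c(Cl)cc(N/C=N/OC)cc1Cl`, gives 3.3. Compound 3 therefore stands second highest of the three: compound 2 lies nearer, a little lower, and compound 1 lies furthest, well above it.

Going by the values given here, only one step between measured compounds differs in a single place, and it runs a number 2.00 log units lower from compound 1 to compound 2 (beyond the scatter). That step swaps one group on an aromatic carbon for another and says nothing directly about the change now at hand.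

Compound 4, `C#CCc1c(Cl)cc(N/C=N/OCC(=O)OCC)cc1Cl`, differs from compound 3 in one place: ethoxycarbonyl in place of hydrogen on a saturated chain carbon bound to an oxygen. Among the compounds with values here, no measured pair here makes this kind of change, so the expectation has to rest on the general experience that a change at the chain end, away from the aromatic ring, tends to move this assay far less than the ethyl-to-ethylsulfonyl swap did. The expected step from compound 3 to compound 4 in this assay is therefore small, a number 0.10 log units lower from compound 3 to compound 4 (within the scatter), in no direction that can be asserted beyond the scatter. For compound 4 the estimate is 3.2, within a range from 2.6 to 3.8.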

Compound 4, partition coefficient: 3.6
The estimate for compound 4 lay 0.40 log units below the measured number; measured number inside the range.
By their numbers in this assay, from the lowest: compound 2; then compounds 3 and 4 (each within the scatter of the next); then compound 1.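

Placing ethoxycarbonyl in place of hydrogen on a saturated chain carbon bound to an oxygen gives, in this assay, a number 0.30 log units higher from compound 3 to compound 4 (within the scatter). Going by these compounds alone, a group of 5 heavy atoms, with 2 hydrogen-bond acceptors and no hydrogen-bond donors, can therefore enter at this place without this read-out telling the two compounds apart, whereas the earlier compounds showed only a change on an aromatic carbon, with a number 2.00 log units lower from compound 1 to compound 2 (beyond the scatter). Nothing measured here offers an explanation for this result.

This is a single change at a single place, so it cannot show whether the same result would hold for other groups there, such as a carboxylic acid, an amine or a longer carbon chain. It also leaves open whether ethoxycarbonyl would behave the same way when the group on the aromatic carbon is ethyl or ethylsulfonyl, as in compound 1 and compound 2, rather than the group carried by compound 3.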